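The source may hold more compounds than are shown below. What is called first, only, known or untested is meant among the compounds shown, and "the series" means these compounds.

In a functional assay on HCT-116 cells (Homo sapiens) for inhibition, read by MTT assay, with a stated time of 48 h (on this read-out lower numbers stand for stronger inhibition and higher numbers for weaker inhibition), compound 1 `CCC(=O)N(Cc1ccc(OC)c(O)c1)c1cc(OC)c(OC)c(OC)c1` gives 61 nM, the lowest of the three numbers measured. Within the data shown here, compound 2 `COc1ccc(CNc2cc(OC)c(OC)c(OC)c2)cc1C` gives 60900 nM and compound 3 `COc1ccc(CNc2cc(OC)c(OC)c(OC)c2)cc1Br` gives 48100 nM; both lie far above compound 1, beyond the scatter, and both differ from compound 1 in more than one place, so no single step links either of them to it. Among the measured compounds shown here, the only step recorded, a 1.3-fold lower number from compound 2 to compound 3 (0.10 log units; within the scatter), concerns a change on an aromatic carbon and lies within the scatter.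

Compound 4 `C#CC(=O)N(Cc1ccc(OC)c(O)c1)c1cc(OC)c(OC)c(OC)c1` differs from compound 1 by ethynyl in place of ethyl on a carbonyl carbon. For the measured compounds named here, no measured step bears on this position: the change from compound 2 to compound 3 sits elsewhere and says nothing about the carbonyl. With no evidence pointing in either direction, the expected step is a 1.5-fold higher number from compound 1 to compound 4 (0.17 log units; within the scatter), within the scatter or leaning a little toward weaker inhibition. The estimate for compound 4 in this assay is therefore 90 nM, with a range from 20 nM to 400 nM.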

Compound 4, half-maximal inhibitory concentration: 310 nM
Compound 4: the middle estimate sits 3.4-fold (0.54 log units) below what was measured; measured number inside the range.
By their numbers in this assay, from the lowest: compound 1; then compound 4; then compounds 3 and 2 (each within the scatter of the next).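

Putting ethynyl in place of ethyl on the carbonyl carbon gives a 5.1-fold higher number from compound 1 to compound 4 (0.71 log units; beyond the scatter) in this assay, so this position is sensitive to which group it carries, even though the two groups have the same count of heavy atoms and neither has a hydrogen-bond donor or acceptor. The step is modest, and compound 4 at 310 nM shows that this position accepts ethynyl with only a limited loss of inhibition. Nothing measured here accounts for the direction of this step.

From the compounds shown here alone, whether a longer chain, a cyclopropyl ring or an amine on this carbonyl carbon would keep the number of compound 1 remains open. So does the question of whether vinyl, with a double bond, would fall nearer to ethyl or to ethynyl.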